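A phenyl swap where only limits are known

The source may hold more compounds than are shown below. What is called first, only, known or untested is meant among the compounds shown, and "the series" means these compounds.

Measured in an ADME assay on microsomes from liver (Canis lupus familiaris) for metabolic stability; on this read-out higher numbers stand for a longer-lived compound and lower numbers for a shorter-lived compound:
compound 1 `Clc1ccc(-c2nc(NCCNc3ccccn3)ncc2-c2ncc[nH]2)c(Cl)c1`: > 0.5 h (a limit)
compound 2 `Nc1nc(NCCNc2ncc(-c3ncc[nH]3)c(-c3ccc(C(F)(F)F)cc3)n2)ccc1[N+](=O)[O-]`: > 0.5 h (a limit)

Compound 2 has no exact number in this assay, only the limit > 0.5 h. Compound 1 offers no firmer footing, as both compounds share (the limit of > 0.5 h in this assay, at which 2 of the 2 values shown sit). Compound 3 `Nc1nc(NCCNc2ncc(-c3ncc[nH]3)c(-c3ccc(F)cc3F)n2)ccc1[N+](=O)[O-]` carries 2,4-difluorophenyl in place of 4-(trifluoromethyl)phenyl on an aromatic carbon. Among the compounds with values here, no measured pair shows what such a swap does, so no change beyond the usual scatter is expected, in either direction. The expected change is a number no higher from compound 2 to compound 3 (the limit leaves the size open). For compound 3 the estimated half-life is 0.5 h, with an expected range of 0.25 h to 1 h.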

Compound 3, half-life: > 0.5 h
Compound 3 ended at the assay's limit; the forecaster's own chance of this, stated with the estimate: 70%; the middle value lies on the limit itself.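

Within the data shown here, compound 2 and compound 3 each give only a limit, not a number, so no step between them can be read: the limit of > 0.5 h in this assay, at which 3 of the 3 values shown sit. Going by these compounds, the actual half-lives of compound 1, compound 2 and compound 3 stay open, and so does the effect of 2,4-difluorophenyl in place of 4-(trifluoromethyl)phenyl.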